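Replacing a cyanophenyl by a dimethylphenyl in compound 1

The source may hold more compounds than are shown below. What is called first, only, known or untested is meant among the compounds shown, and "the series" means these compounds.

Of the compounds shown here, three have so far been measured in an ADME assay on HepG2 cells (Homo sapiens) for cytotoxicity, read by luminescence, CellTiter-Glo and ATP content, with a stated time of 72 h; a lower number here means that less compound is needed, a higher number that more compound is needed for the effect. Compound 1 `COc1ccc(F)cc1CNCCCNc1ccnc2cc(Cc3ccc(C#N)cc3)ccc12` gives 6050 nM, which places it second highest among the three numbers. Among the measured compounds shown here, its nearest neighbour is compound 3 `COc1cccc(CNCCCNc2ccnc3cc(Cc4ccc(C#N)cc4)ccc23)c1O`, which gives 7150 nM; the only single-point step among the measured compounds is a 1.2-fold higher number from compound 1 to compound 3 (0.07 log units; within the scatter). Farthest from compound 1 lies compound 2 `FC(F)(F)c1ccc(-c2ccc3c(NCCCNCc4ccco4)ccnc3c2)cc1`, which in this assay gives 3470 nM, a gap that also remains within the scatter, although compound 2 differs from compound 1 in more than one place, so no single step can be read from that pair.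

The unmeasured compound 4 `COc1ccc(F)cc1CNCCCNc1ccnc2cc(Cc3cc(C)cc(C)c3)ccc12` is reached from compound 1 by a change at a different place from the one probed so far: 3,5-dimethylphenyl in place of 4-cyanophenyl on a saturated chain carbon bound to an aromatic carbon. For the measured compounds named here, no measured step touches a saturated chain carbon bound to an aromatic carbon; the one available step sits on the chain carbon bound to the amine nitrogen and stayed within the scatter, and the three measured numbers spread little overall. The expectation for compound 4 is therefore a step of a 1.2-fold lower number from compound 1 to compound 4 (0.08 log units; within the scatter), that is, none beyond the scatter. The estimate for compound 4 is 5000 nM, with a range from 2200 nM to 11000 nM.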

Compound 4, half-maximal effective concentration: 940 nM
Beside the measured number, compound 4's estimate is 5.3-fold (0.73 log units) above it; the measured number lies below the stated range.
By their numbers in this assay, from the lowest: compound 4; then compounds 2, 1 and 3 (each within the scatter of the next, the first and the last beyond it).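

In this assay the exchange of 4-cyanobenzyl for 3,5-dimethylbenzyl gives a 6.4-fold lower number from compound 1 to compound 4 (0.81 log units; beyond the scatter), whereas the earlier change on a saturated chain carbon bound to an amine nitrogen, a 1.2-fold higher number from compound 1 to compound 3 (0.07 log units; within the scatter), stayed within the scatter. The place on a saturated chain carbon bound to an aromatic carbon is therefore the first in this series where a single change has moved the number beyond the scatter, and here the move is towards less compound being needed for the effect. The two groups have the same heavy-atom count, but the change removes the nitrile with its triple bond and hydrogen-bond acceptor and adds two methyl groups, and no measurement shown here explains the step or assigns it to either part of the change.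

The compounds shown do not separate the loss of the nitrile from the gain of the methyl groups, which a plain phenyl or a ring carrying a single methyl group could do. They also leave open whether 3,5-dimethylphenyl gives a similar step alongside the 2-hydroxy-3-methoxyphenyl group of compound 3 or the furan-bearing chain of compound 2.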